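Biphenyl para substituent: methyl to methoxy

This account rests on a few compounds, and the source may have more. Where it says the series, first, only, none or still open, it means among the compounds named here.

Compound 1 `CC(C)C[C@H](N)CN(C(=O)[C@@H]1C[C@H]1c1ccccc1)c1ccc(-c2ccccc2)cc1` gives 880 nM in a functional assay for agonist activity at G protein-coupled receptor 88 (Homo sapiens), read by HTRF and cAMP accumulation; a higher number here means that more compound is needed for the effect, a lower number that less compound is needed. Going by the values given here, compound 2 `Cc1ccc(-c2ccc(N(C[C@@H](N)CC(C)C)C(=O)[C@@H]3C[C@H]3c3ccccc3)cc2)cc1` gives 360 nM in this assay, the lowest of the two numbers so far, reached with a 2.4-fold lower number from compound 1 to compound 2 (0.39 log units; beyond the scatter). Compound 3 `COc1ccc(-c2ccc(N(C[C@@H](N)CC(C)C)C(=O)[C@@H]3C[C@H]3c3ccccc3)cc2)cc1` differs from compound 2 by methoxy in place of methyl on an aromatic carbon, para to a large group. Among the compounds with values here, no measured step swaps a methyl for a methoxy; the only step on that aromatic carbon, a 2.4-fold lower number from compound 1 to compound 2 (0.39 log units; beyond the scatter), added the methyl itself. For compound 3 the step in this assay is therefore expected to be small, a 1.1-fold higher number from compound 2 to compound 3 (0.05 log units; within the scatter), with no direction clearly beyond the scatter. Compound 3 is estimated at 400 nM, range 150 nM to 1100 nM.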

Compound 3, half-maximal effective concentration: 330 nM
The estimate for compound 3 lay 1.2-fold (0.08 log units) above the measured number, and the stated range covers the measured number.
By their numbers in this assay, from the lowest: compounds 3 and 2 (each within the scatter of the next); then compound 1.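

In this assay, the change from 4-methylphenyl to 4-methoxyphenyl gives a 1.1-fold lower number from compound 2 to compound 3 (0.04 log units; within the scatter), so at this position the extra oxygen, with its hydrogen-bond acceptor, leaves the number within the scatter. Methoxy in place of hydrogen gives a 2.7-fold lower number from compound 1 to compound 3 (0.43 log units; beyond the scatter), making methoxy the second group on this aromatic carbon, after methyl, with a step beyond the scatter. No available evidence bears on this result.

On these data alone, whether a longer chain such as ethoxy keeps this number remains open. So does the effect of an amine or a carboxylic acid on this carbon.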